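Working notes: compound 3 to compound 4

A few compounds are considered here, and "the series" means these few. Any claim that something is new, unique, unknown or untested is made for them only; others in the source may bear on it.

Readings in a functional assay on HUVEC cells (Homo sapiens) for inhibition, with stated times of 2 h and 72 h (a higher number here means a weaker inhibitor, a lower number a stronger inhibitor), with each entry a limit and not a number
- compound 1 `COc1cc2nccc(Oc3ccc4c(NC(=O)c5cc(Cl)ccn5)nn(C)c4c3)c2cc1OC` gives > 1000 nM as a limit
- compound 2 `COc1ccc(C(=O)Nc2nn(C)c3cc(Oc4ccnc5cc(OC)c(OC)cc45)ccc23)cc1` gives > 1000 nM as a limit
- compound 3 `COc1cc2nccc(Oc3ccc4c(NC(=O)c5cccc(C)c5)nn(C)c4c3)c2cc1OC` gives > 1000 nM as a limit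

Compound 3 has no number of its own, and the set as a whole reads the limit of > 1000 nM in this assay, at which 3 of the 3 values shown sit, with nothing yet resolved. Next comes compound 4 `COc1ccc(Nc2nn(C)c3cc(Oc4ccnc5cc(OC)c(OC)cc45)ccc23)cc1` with the change 4-methoxyphenyl in place of (3-methylphenyl)carbonyl on a nitrogen on an aromatic ring so the carbonyl leaves along with the 3-methylphenyl. The nearest measured evidence is a step that the two limits leave unreadable from compound 1 to compound 3 and also a step that the two limits leave unreadable from compound 2 to compound 3 and neither gives a size to carry over. Going by the values given here, both swap the group on a carbonyl carbon, and no measured step removes the carbonyl. Compound 2 shares the 4-methoxyphenyl with compound 4, but without that change. No direction can therefore be argued in this assay and a further limit is the likeliest expected outcome. The expected step is a step that the limit leaves unreadable from compound 3 to compound 4 as a rough estimate only. For compound 4 the estimated value is 2000 nM with an expected range from 400 nM to 10000 nM in this assay.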

Compound 4, half-maximal inhibitory concentration: > 1000 nM
Compound 4 was reported as a limit; the forecaster's own chance of this, stated with the estimate: 70%; the middle value is on the limit's open side.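

In this assay compound 4 gives > 1000 nM, which is a limit, so its steps from compound 1, compound 2 and compound 3 cannot be read. The compounds shown leave open how strongly any of them inhibits, and whether any change in the series alters that, as every reading stays unresolved: the limit of > 1000 nM in this assay, at which 4 of the 4 values shown sit.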